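Trifluoromethyl to Cyano on a Shared Core

The source may hold more compounds than are shown below. What is called first, only, known or untested is meant among the compounds shown, and "the series" means these compounds.

Compound 1 `Cc1ccc(C2=NN(c3nc(-c4ccc(S(C)(=O)=O)cc4)cs3)C(c3ccc(F)cc3)C2)s1` carries a methylsulfonyl group on an aromatic carbon. In an ADME assay on NIH3T3 cells (Mus musculus) for cytotoxicity, read by XTT assay, with a stated time of 24 h (a higher number here means a weaker inhibitor, a lower number a stronger inhibitor), compound 1 gives 374 ug/mL. Compound 2 `Cc1ccc(C2=NN(c3nc(-c4ccc(C(F)(F)F)cc4)cs3)C(c3ccc(F)cc3)C2)s1` carries a trifluoromethyl group at the same place instead. In this assay compound 2 reaches only a limit of the measurement, > 500 ug/mL. The step of an at least 1.3-fold higher number from compound 1 to compound 2 (0.12 log units; that floor lies within the scatter) cannot be sized more closely because of the limit of > 500 ug/mL in this assay, at which 1 of the 2 values shown sits. Compound 2 thus stands at the upper edge of what this measurement reports, and its separation from compound 1 is only a floor within the scatter.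

Compound 3 `Cc1ccc(C2=NN(c3nc(-c4ccc(C#N)cc4)cs3)C(c3ccc(F)cc3)C2)s1` differs from compound 2 by cyano in place of trifluoromethyl on an aromatic carbon. For the measured compounds named here, no measured step changes a trifluoromethyl into a cyano, so the only guide is the step from compound 1 to compound 2, in which exchanging the group at this position moved the number by a floor that sits within the scatter. Compound 3 is therefore expected to sit near the limit as well, with an at least 1.1-fold lower number from compound 2 to compound 3 (0.04 log units; that floor lies within the scatter) expected to be small and in no clear direction. The estimate for compound 3 in this assay is 450 ug/mL, expected to fall between 220 ug/mL and 900 ug/mL.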

Compound 3, half-maximal inhibitory concentration: 250 ug/mL
For compound 3 the middle estimate is 1.8-fold (0.26 log units) above the measured one; the measured number falls inside the stated range.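

Cyano now gives a real number at the position where methylsulfonyl did, so two groups on this aromatic carbon can be compared directly in this assay for the first time, and the step of a 1.5-fold lower number from compound 1 to compound 3 (0.17 log units; within the scatter) places these two groups within the usual spread of repeats. The other step, an at least 2.0-fold lower number from compound 2 to compound 3 (0.30 log units; that floor lies within the scatter), gives only a floor, so with trifluoromethyl, methylsulfonyl and cyano all tried here, no exchange at this position has yet been shown to move the number beyond the scatter. That floor cannot be turned into a sized step because the value for compound 2 is a limit of the measurement and not a number: the limit of > 500 ug/mL in this assay, at which 1 of the 3 values shown sits.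

From the compounds shown here alone, how far the true value of compound 2 lies from that limit stays open, so the real size of the exchange from trifluoromethyl to cyano remains unknown. Also open, going by these compounds, is whether a quite different group at this place, such as an amine or a carboxylic acid, would produce a step that clears the scatter in this assay.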